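Ring-nitrogen substituent: methyl, isopentyl, then cyclopropyl

The compounds below may be only part of what the source reports. "The series", "measured", "known", "first", "only" and "open" are said of these compounds alone.

Measured compounds:
compound 1, `Cn1sc2cc(OCc3cccc(-c4ccc(Cl)c(C(=O)O)c4)c3)ccc2c1=O`: 640 nM
compound 2, `CC(C)CCn1sc2cc(OCc3cccc(-c4ccc(Cl)c(C(=O)O)c4)c3)ccc2c1=O`: 650 nM

In an assay on HEK293 cells for positive allosteric modulation of metabotropic glutamate receptor 2 (Rattus norvegicus), read by thallium flux (on this read-out higher numbers stand for an effect only at larger amounts of compound and lower numbers for an effect already at smaller amounts), compound 1 gives 640 nM and compound 2 gives 650 nM. Compound 2 holds the higher of the two numbers, but only nominally: the step of a 1.0-fold higher number from compound 1 to compound 2 (0.01 log units; within the scatter) is flat, so the two compounds cannot be told apart on this read-out.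

Compound 3 `O=C(O)c1cc(-c2cccc(COc3ccc4c(=O)n(C5CC5)sc4c3)c2)ccc1Cl` has not been measured in this assay. It differs from compound 2 in one place: cyclopropyl in place of isopentyl on an aromatic nitrogen. Within the data shown here, the one measured step that bears on this position is a 1.0-fold higher number from compound 1 to compound 2 (0.01 log units; within the scatter), in which replacing the smallest possible substituent on the ring nitrogen by a branched chain left the number where it was. Cyclopropyl is another small, uncharged carbon group without donors or acceptors at the same nitrogen, so no step beyond the scatter is expected in this assay.

For compound 3 the expected value is 650 nM, with a range from 300 nM to 1400 nM. This estimate corresponds to a step of no change at the digits printed from compound 2 to compound 3 (within the scatter) in this assay, expected to stay within the scatter.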

Compound 3, half-maximal effective concentration: 130 nM
The estimate for compound 3 lay 5.0-fold (0.70 log units) above the measured number, and the stated range ends above it.
By their numbers in this assay, from the lowest: compound 3; then compounds 1 and 2 (each within the scatter of the next).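

In this assay the ring-nitrogen position turns out to respond to its substituent: cyclopropyl in place of isopentyl gives a 5.0-fold lower number from compound 2 to compound 3 (0.70 log units; beyond the scatter), and cyclopropyl in place of methyl gives a 4.9-fold lower number from compound 1 to compound 3 (0.69 log units; beyond the scatter), so the flat step a 1.0-fold higher number from compound 1 to compound 2 (0.01 log units; within the scatter) did not mean that any small carbon group would do here. Heavy-atom count alone does not order the three compounds, since methyl and isopentyl give numbers within the scatter of each other while cyclopropyl stands apart from both, and among these three only compound 3 carries a ring on this nitrogen. Nothing available accounts for the lower number of compound 3.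

Still open, from the compounds shown here alone, is whether this step belongs to the three-membered ring itself or would also appear with a cyclobutyl or cyclopentyl ring, or with an open branched group of similar size such as isopropyl. Also open, going by these compounds, is how this nitrogen responds to a substituent that contains a heteroatom, such as a hydroxyethyl chain or an amine.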